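This account rests on a few compounds, and the source may have more. Where it says the series, first, only, none or still open, it means among the compounds named here.

In a functional assay on HepG2 cells (Homo sapiens) for inhibition, read by MTT assay, with a stated time of 72 h (on this read-out lower numbers stand for stronger inhibition and higher numbers for weaker inhibition), compound 1, `CNc1nc(C(F)(F)F)c(C(=O)N/N=C/c2cccc(C(F)(F)F)c2)s1`, gives > 100 ug/mL, which is a limit of the assay rather than a number. Within the data shown here, compound 2, `CN(C(=O)NC(=O)c1ccc([N+](=O)[O-])cc1)c1nc(C(F)(F)F)c(C(=O)N/N=C/c2cccc(C(F)(F)F)c2)s1`, is the only compound of the two that returns a measured value, 4.73 ug/mL in this assay; the other value is the limit of > 100 ug/mL in this assay, at which 1 of the 2 values shown sits. Compound 3, `CN(C(=O)NC(=O)c1ccccc1F)c1nc(C(F)(F)F)c(C(=O)N/N=C/c2cccc(C(F)(F)F)c2)s1`, differs from compound 2 by a single exchange, (2-fluorophenyl in place of 4-nitrophenyl on a carbonyl carbon). Among the measured compounds shown here, no measured pair separates these two groups, so the direction of the step rests on no comparison within the data. The account expects the step from compound 2 to compound 3 to be a 2.5-fold higher number from compound 2 to compound 3 (0.40 log units; beyond the scatter), a modest weakening that reaches beyond the usual scatter but stays well clear of the limit. On that expectation compound 3 is estimated at 12 ug/mL in this assay, with a range from 3 ug/mL to 45 ug/mL.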

Compound 3, half-maximal inhibitory concentration: 20.3 ug/mL
Compound 3: the middle estimate sits 1.7-fold (0.23 log units) below what was measured; the measured number falls inside the stated range.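

In this assay the exchange on this carbonyl carbon gives a 4.3-fold higher number from compound 2 to compound 3 (0.63 log units; beyond the scatter) and so shows that the group held there changes the read-out, with 2-fluorophenyl weaker than 4-nitrophenyl. With an at least 4.9-fold lower number from compound 1 to compound 3 (0.69 log units; beyond the scatter) as well, the gain over compound 1 no longer rests on 4-nitrophenyl alone, since a second aryl carbonyl group also gives a measurable value. Compound 1 stands at a limit of the assay, so that second step is a bound rather than a full size: the limit of > 100 ug/mL in this assay, at which 1 of the 3 values shown sits.

With one exchange shown, the compounds do not separate the loss of the nitro group from the entry of the fluorine, or show what the place of either on the ring contributes. On these data alone, how a plain phenyl, a 2-nitrophenyl or a methyl group would read on this carbonyl carbon stays open.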